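The compounds below may be only part of what the source reports. "The series", "measured", "known", "first", "only" and "open" are said of these compounds alone.

Measured so far:
compound 1, `CC(=O)Oc1ccc2cc(-n3cc(-c4ccccc4)nn3)c(=O)oc2c1C`: 40800 nM
compound 2, `CO[C@@H]1[C@@H](O)[C@@H](O)[C@H](Oc2ccc3c(c2C)OC(=O)C(n2cc(-c4ccccc4)nn2)C3)OC1(C)C`: 64400 nM

Compound 2 was tested in a functional assay on MCF7 cells (Homo sapiens) for antiproliferative activity (on this read-out lower numbers stand for stronger inhibition and higher numbers for weaker inhibition), where compound 2 gives 64400 nM. Compound 1 gives 40800 nM in this assay, and the gap between the two numbers lies within the usual scatter of repeated measurements, so nothing can be read into which of them comes out higher; the two compounds simply share the same weak range. Compound 3, `CO[C@@H]1[C@@H](O)[C@@H](O)[C@H](Oc2ccc3c(c2C)OC(=O)C(n2cc(-c4ccc(C)cc4)nn2)C3)OC1(C)C`, has not yet been measured. It differs from compound 2 in one place: methyl in place of hydrogen on an aromatic carbon. Within the data shown here, no step between two measured compounds is available that would show what this change does in this assay, and the two measured numbers give no direction to build on. The author therefore expects no step beyond the scatter, and the expected step is a 1.1-fold lower number from compound 2 to compound 3 (0.03 log units; within the scatter). On that basis compound 3 is estimated in this assay at 60000 nM, with a range from 25000 nM to 150000 nM, and the measurement will show whether that expectation holds.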

Compound 3, half-maximal inhibitory concentration: > 100000 nM
Compound 3: no number, only a limit; the forecaster's own chance of this, stated with the estimate: 25%; middle value at least 1.6-fold (0.22 log units) away from the limit.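

In this assay compound 3 gives > 100000 nM as a limit of the assay and not as a number. The change from phenyl to 4-methylphenyl brings an at least 1.5-fold higher number from compound 2 to compound 3 (0.19 log units; that floor lies within the scatter) and the floor of that step lies within the scatter, so this methyl shows no sign of strengthening inhibition, while a real weakening can be neither claimed nor excluded. The true size of the step cannot be read because the value of compound 3 stands at a limit: the limit of > 100000 nM in this assay, at which 1 of the 3 values shown sits.

The compounds shown carry only hydrogen and methyl at this place on the phenyl, so it stays open whether a methoxy group, a chlorine atom or an amine there would bring the number down or push it up. Compound 1 differs from compound 2 in more than one place, and nothing here tells whether the same methyl would act alike on the core of compound 1 or whether the sugar-like group of compound 2 has any bearing on the outcome.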